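Moving a methyl between two sulfamide nitrogens

A few compounds are considered here, and "the series" means these few. Any claim that something is new, unique, unknown or untested is made for them only; others in the source may bear on it.

Compound 1, `CCN1CCCC1CNC(=O)c1cc(NS(=O)(=O)N(C)C)ccc1OC`: 1 mg/kg
Compound 2, `CCN1CCCC1CNC(=O)c1cc(NS(C)(=O)=O)ccc1OC`: 2 mg/kg
Compound 3, `CCN1CCCC1CNC(=O)c1cc(NS(=O)(=O)NC)ccc1OC`: > 1 mg/kg, which is a limit

All three share one core and were tested in a functional assay on the whole organism for inhibition, with Canis familiaris (Canis lupus familiaris) as the target; on this read-out lower numbers stand for an effect already at smaller amounts and higher numbers for an effect only at larger amounts of compound. In this assay compound 1 gives 1 mg/kg and compound 2 gives 2 mg/kg, so there is a 2.0-fold higher number from compound 1 to compound 2 (0.30 log units; within the scatter). For compound 3 this assay reports only a limit, > 1 mg/kg. Compound 3 therefore stands at the limit of > 1 mg/kg in this assay, at which 1 of the 3 values shown sits, with a number no lower from compound 1 to compound 3 (the limit leaves the size open) and a step that the limit leaves unreadable from compound 2 to compound 3.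

Compound 4, `CCN1CCCC1CNC(=O)c1cc(N(C)S(N)(=O)=O)ccc1OC`, differs from compound 3 by methyl(sulfamoyl)amino in place of (methylsulfamoyl)amino on an aromatic carbon. For the measured compounds named here, none of the measured steps moves a methyl between the two nitrogens; the only readable step, from compound 1 to compound 2, lies within the scatter, and the limit for compound 3 leaves the other two open. In this assay no step beyond the scatter is expected, and a limit again is plausible. The estimate implies an expected step that the limit leaves unreadable from compound 3 to compound 4. Compound 4 is thus estimated at 2 mg/kg, with a range from 0.5 mg/kg to 8 mg/kg.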

Compound 4, dose for half-maximal effect: 1 mg/kg
Beside the measured number, compound 4's estimate is 2.0-fold (0.30 log units) above it; the measured number falls inside the stated range.
By their numbers in this assay, from the lowest: compounds 1, 4 and 2 (each within the scatter of the next).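

In this assay, the step to methyl(sulfamoyl)amino from methanesulfonamido gives a 2.0-fold lower number from compound 2 to compound 4 (0.30 log units; within the scatter), and the step from (dimethylsulfamoyl)amino gives no change at the digits printed from compound 1 to compound 4 (within the scatter). The aromatic carbon para to a methoxy group therefore carries a sulfamide with its methyl on the nitrogen bound to that carbon, and the number stays within the scatter of both neighbours. The step from the isomeric (methylsulfamoyl)amino group gives a number no higher from compound 3 to compound 4 (the limit leaves the size open). Its size cannot be read, because compound 3 has only a limit: the limit of > 1 mg/kg in this assay, at which 1 of the 4 values shown sits.

Going by these compounds, what moving the methyl does to the number therefore stays open, as the isomeric pair gives no readable size. Also open, on these data alone, is whether a longer chain such as ethyl on the nitrogen bound to the aromatic carbon, or a carboxylic acid in place of the sulfamide, would keep the number within this range.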